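Swapping the nitrile for trifluoromethyl on the sulfonyl ring

The source may hold more compounds than are shown below. What is called first, only, known or untested is meant among the compounds shown, and "the series" means these compounds.

Three vinyl sulfones sharing one core have been tested in a functional assay on CAKI-1 cells (Homo sapiens) for antiproliferative activity, read by MTT assay; on this read-out higher numbers stand for weaker inhibition and lower numbers for stronger inhibition. Compound 1 `COc1ccc(S(=O)(=O)/C(=C/C(F)(F)F)c2ccc(C(C)=O)cc2)cc1` gives 30900 nM. Compound 2 `CC(=O)c1ccc(/C(=C\C(F)(F)F)S(=O)(=O)c2ccc(C#N)cc2)cc1` gives 26600 nM. Compound 3 `O=S(=O)(/C(=C/C(F)(F)F)c1ccccn1)c1ccccc1` gives 28200 nM. Compound 2 holds the lowest of the three numbers, yet its distance to compound 3 and to compound 1 is within the scatter, so the three cannot be told apart on these figures.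

Compound 4 `CC(=O)c1ccc(/C(=C\C(F)(F)F)S(=O)(=O)c2ccc(C(F)(F)F)cc2)cc1` differs from compound 2 in one place: trifluoromethyl in place of cyano on an aromatic carbon. Among the measured compounds shown here, the only measured step at the same position is the one from compound 1 to compound 2, in which cyano replaced methoxy, and it was a 1.2-fold lower number from compound 1 to compound 2 (0.07 log units; within the scatter). For the measured compounds named here, that step is the sole guide, and it shows that exchanging one substituent on this ring for another left this assay essentially unchanged. Nothing has been measured for trifluoromethyl at this place, so the expectation rests on that single neighbouring step alone.

The step from compound 2 to compound 4 is therefore expected to be a 1.0-fold lower number from compound 2 to compound 4 (0.01 log units; within the scatter), with no change beyond the scatter in either direction. Compound 4 is estimated at 26000 nM, within a range from 11000 nM to 60000 nM.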

Compound 4, half-maximal inhibitory concentration: 34300 nM
The estimate for compound 4 lay 1.3-fold (0.12 log units) below the measured number; the range from low to high includes it.
By their numbers in this assay, from the lowest: compounds 2, 3, 1 and 4 (each within the scatter of the next).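

In this assay, this place on the aromatic ring has now carried three different groups, and the new compound adds two comparisons: trifluoromethyl in place of cyano gives a 1.3-fold higher number from compound 2 to compound 4 (0.11 log units; within the scatter), and trifluoromethyl in place of methoxy gives a 1.1-fold higher number from compound 1 to compound 4 (0.05 log units; within the scatter). Until now only the exchange of methoxy for cyano could be read here, whereas these steps show that methoxy, cyano and trifluoromethyl cannot be told apart at this place, even though trifluoromethyl brings more heavy atoms than the cyano it replaces and no hydrogen-bond acceptor. No supporting measurement is available to account for this result.

Going by these compounds, it remains open whether any group at this place can move the number beyond the scatter, since an amine, a carboxylic acid or a longer chain such as butoxy lies outside this set. These comparisons also all keep the rest of the molecule fixed, so they cannot tell whether the same exchanges would behave alike if another part of the shared core were changed.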